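Fluoro for Chloro on the Benzylsulfanyl Group

The source may report more compounds than this note shows. Statements on the series, on what has been measured and on what is new or still open speak of the compounds shown alone.

In a functional assay on the whole organism (artery, strain albino) with Rattus norvegicus as the target, with a stated time of 15 min, at a dose of 10 mg/kg by the oral route (a lower number here means less inhibition, a higher number more inhibition at the dose given (going by the name of the read-out)), the measured compounds stand as follows:
compound 1 `CC1=C(C(=O)Nc2ccc(F)cc2)C(c2ccc([N+](=O)[O-])cc2)N=C(SCc2ccc(Cl)cc2)N1` gives 3.6%;
compound 2 `CC1=C(C(=O)Nc2ccc(F)cc2)C(c2ccc([N+](=O)[O-])cc2)N=C(SCc2ccc(F)cc2)N1` gives 3.1%;
compound 3 `CC1=C(C(=O)Nc2ccc(Br)cc2)C(c2ccc(Cl)cc2Cl)N=C(SCc2ccc(Cl)cc2)N1` gives 4.1%.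

All three show little inhibition at the dose tested. Compound 1 and compound 2 differ in one place, (fluoro in place of chloro on an aromatic carbon), and the step of a number 0.5 percentage points lower from compound 1 to compound 2 (within the scatter). How the core of compound 3 differs from the core of compound 1 is not broken down here. Compound 4 `CC1=C(C(=O)Nc2ccc(Br)cc2)C(c2ccc(Cl)cc2Cl)N=C(SCc2ccc(F)cc2)N1`, not yet measured, differs from compound 3 by fluoro in place of chloro on an aromatic carbon, the same change as between compound 1 and compound 2, at a place described in the same words. Because the earlier step of a number 0.5 percentage points lower from compound 1 to compound 2 (within the scatter) stayed within the scatter, compound 4 is expected to show a number 0.5 percentage points lower from compound 3 to compound 4 (within the scatter), again within the scatter. Compound 4 is estimated at 3.6% in this assay, between 0% and 12%.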

Compound 4, a percentage reported as inhibition, in the whole organism at one dose (the size of the read-out at that dose, not a potency): 3.6%
Compound 4: the middle estimate sits on the measured number at the digits printed; the measured number falls inside the stated range.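

In this assay, putting fluoro in place of chloro on the core of compound 3 makes the read-out come out a number 0.5 percentage points lower from compound 3 to compound 4 (within the scatter). On both cores the change stays within the scatter, and the two steps agree: the same change on two cores in this assay, a number 0.5 percentage points lower (within the scatter) from compound 1 to compound 2 and a number 0.5 percentage points lower (within the scatter) from compound 3 to compound 4, 0 percentage points apart, within the scatter of two such steps
This shows that the swap left the result unmoved on both cores, but with all four compounds showing little inhibition, it cannot show how the same change would behave on a core with strong inhibition.

The compounds shown leave open what other groups on the benzyl ring would do. An amine or a carboxylic acid in place of the halogen, or a longer chain in place of the (4-chlorobenzyl)sulfanyl group, might give a different result.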